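The source may hold more compounds than are shown below. What is called first, only, known or untested is meant among the compounds shown, and "the series" means these compounds.

In a functional assay on HCT-116 cells (Homo sapiens), read by MTT assay, with a stated time of 72 h (a higher number here means a weaker inhibitor, a lower number a stronger inhibitor), compound 1 `Nc1nc2c(c(-c3ccccc3)cn2[C@@H]2O[C@H](CO)[C@@H](O)[C@H]2O)c(=O)[nH]1` gives only a limit, > 20000 nM. Compound 2 `O=c1[nH]cnc2c1c(-c1ccsc1)cn2[C@@H]1O[C@H](CO)[C@@H](O)[C@H]1O` likewise gives only a limit, > 20000 nM. Compound 3 `O=c1[nH]cnc2c1c(-c1ccco1)cn2[C@@H]1O[C@H](CO)[C@@H](O)[C@H]1O` gives 18300 nM.

Compound 3 is thus the only one of the three with a number in this assay; the other two sit at the limit of > 20000 nM in this assay, at which 2 of the 3 values shown sit. Compound 4 `O=c1[nH]cnc2c1c(-c1ccccc1)cn2[C@@H]1O[C@H](CO)[C@@H](O)[C@H]1O` differs from compound 3 by phenyl in place of furan-2-yl on an aromatic carbon. For the measured compounds named here, one measured step bears on this change, the exchange of one five-membered ring for another on an aromatic carbon, an at least 1.0-fold lower number from compound 2 to compound 3 (0.03 log units; that floor lies within the scatter), which stayed within the scatter. Compound 1 also bears a phenyl group and gives only a limit. Compound 4 is therefore expected to show no step beyond the scatter, a 1.1-fold higher number from compound 3 to compound 4 (0.04 log units; within the scatter). The estimate for compound 4 is 20000 nM, with a range from 9000 nM to 45000 nM.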

Compound 4, half-maximal inhibitory concentration: > 100000 nM
Compound 4 was reported as a limit; the forecaster's own chance of this, stated with the estimate: 55%; middle value at least 5.0-fold (0.69 log units) away from the limit.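

On this aromatic carbon, phenyl in place of furan-2-yl gives a step beyond the scatter in this assay: an at least 5.4-fold higher number from compound 3 to compound 4 (0.73 log units; beyond the scatter). The earlier exchange of one five-membered ring for another, an at least 1.0-fold lower number from compound 2 to compound 3 (0.03 log units; that floor lies within the scatter), had stayed within the scatter, so this change shows that the group at this position can move the number measurably, and since compound 4 gives a limit, the step is only a floor. The steps to compound 4 from compound 2 and from compound 1 cannot be read: both ends are limits.

The compounds shown leave open whether an amine or a carboxylic acid on the phenyl ring would give a lower number. They also leave open whether furan-2-yl would still give a measurable number with an amino group on the shared core.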